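Replacing the fluorine of compound 1 with an amino group

A few compounds are considered here, and "the series" means these few. Any claim that something is new, unique, unknown or untested is made for them only; others in the source may bear on it.

Compound 1 `COc1cc(-c2nccn3cc(-c4ccc(F)cc4)nc23)cc(OC)c1OC` carries a fluoro group on its outer phenyl ring, and in a functional assay on MDA-MB-231 cells (Homo sapiens) for inhibition, read by MTT assay, with a stated time of 48 h (a lower number here means a stronger inhibitor, a higher number a weaker inhibitor), compound 1 gives 401 nM, the lowest of the two numbers measured. Compound 2 `COc1cc(-c2nccn3cc(-c4ccc(Cl)cc4)nc23)cc(OC)c1OC` carries a chloro group in the same place; in this assay compound 2 gives 2090 nM. Compound 3 `COc1cc(-c2nccn3cc(-c4ccc([N+](=O)[O-])cc4)nc23)cc(OC)c1OC` carries a nitro group there. In this assay compound 3 reaches only a limit, > 10000 nM, which is not a true number but the edge of what the measurement reports (the limit of > 10000 nM in this assay, at which 1 of the 3 values shown sits).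

The measured steps all move away from the fluoro group and all weaken inhibition: a 5.2-fold higher number from compound 1 to compound 2 (0.72 log units; beyond the scatter), an at least 24-fold higher number from compound 1 to compound 3 (1.39 log units; beyond the scatter), and an at least 4.7-fold higher number from compound 2 to compound 3 (0.67 log units; beyond the scatter).

Compound 4 `COc1cc(-c2nccn3cc(-c4ccc(N)cc4)nc23)cc(OC)c1OC` differs from compound 1 in one respect: amino in place of fluoro on an aromatic carbon. Within the data shown here, no measured pair tests an amino group, so the step cannot be read off directly. Since every replacement of the fluoro group of compound 1 gave a higher number, as in a 5.2-fold higher number from compound 1 to compound 2 (0.72 log units; beyond the scatter) and an at least 24-fold higher number from compound 1 to compound 3 (1.39 log units; beyond the scatter), a modest weakening is expected for compound 4, a 3.7-fold higher number from compound 1 to compound 4 (0.57 log units; beyond the scatter). For compound 4 the estimated value in this assay is 1500 nM, with a likely range from 300 nM to 8000 nM.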

Compound 4, half-maximal inhibitory concentration: 294 nM
The estimate for compound 4 lay 5.1-fold (0.71 log units) above the measured number, outside the stated range (below it).
By their numbers in this assay, from the lowest: compounds 4 and 1 (each within the scatter of the next); then compound 2. At a limit, above all of these: compound 3.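

In this assay, among these compounds, the earlier compounds suggested that any replacement of the fluoro group at this place raises the number, but the amino group of compound 4 goes against that: a 1.4-fold lower number from compound 1 to compound 4 (0.13 log units; within the scatter), so fluoro and amino cannot be told apart here, even though amino brings a hydrogen-bond donor that fluoro lacks. The replacement itself is therefore not what costs inhibition, and the choice of group decides the outcome, as the other two steps show: a 7.1-fold lower number from compound 2 to compound 4 (0.85 log units; beyond the scatter), and an at least 34-fold lower number from compound 3 to compound 4 (1.53 log units; beyond the scatter). The second of these spans two nitrogen-bearing groups at the same place, but its size is only a bound, as compound 3 gives a limit and not a number: the limit of > 10000 nM in this assay, at which 1 of the 4 values shown sits.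

The compounds shown leave open whether the hydrogen-bond donor of the amino group has any part in this result, a question that a methylamino, dimethylamino or hydroxyl group at the same place could help to answer. They also leave open why chloro and nitro stand apart from fluoro and amino, and an acetamido or methoxy group would add further points of comparison.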